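Varying the aryl group on the imine-bearing carbon

The source may report more compounds than this note shows. Statements on the series, on what has been measured and on what is new or still open speak of the compounds shown alone.

Three compounds built on one shared core differ only in the aryl group attached to a carbon with a double bond to nitrogen. In a functional assay on HT-29 cells (Homo sapiens) for cytotoxicity, read by MTT assay, with a stated time of 72 h (on this read-out higher numbers stand for weaker inhibition and lower numbers for stronger inhibition), compound 1 `CN(C)CCn1cnnc1-c1cc(Oc2ccc(NC(=O)N/N=C/c3c(Cl)cccc3Cl)cc2F)ccn1` gives 280 nM. Compound 2 `CN(C)CCn1cnnc1-c1cc(Oc2ccc(NC(=O)N/N=C/c3ccc(O)c(Br)c3)cc2F)ccn1` gives 450 nM in this assay, and compound 3 `CN(C)CCn1cnnc1-c1cc(Oc2ccc(NC(=O)N/N=C/c3ccccc3)cc2F)ccn1` gives 1120 nM. Compound 2 thus holds the second highest of the three numbers: the step of a 1.6-fold higher number from compound 1 to compound 2 (0.21 log units; within the scatter) lies within the scatter, whereas the step of a 2.5-fold higher number from compound 2 to compound 3 (0.40 log units; beyond the scatter) lies beyond it. Compound 4 `COc1cc(/C=N/NC(=O)Nc2ccc(Oc3ccnc(-c4nncn4CCN(C)C)c3)c(F)c2)cc(OC)c1OC` has not yet been measured; it differs from compound 2 by 3,4,5-trimethoxyphenyl in place of 3-bromo-4-hydroxyphenyl on a carbon with a double bond to nitrogen. All three measured steps bear on this change, since each swaps the aryl group on that same carbon: a 1.6-fold higher number from compound 1 to compound 2 (0.21 log units; within the scatter), a 4.0-fold higher number from compound 1 to compound 3 (0.60 log units; beyond the scatter) and a 2.5-fold higher number from compound 2 to compound 3 (0.40 log units; beyond the scatter). Both substituted rings gave lower numbers than the bare phenyl of compound 3, and those two substituted rings sit within the scatter of each other. A third substituted ring is therefore expected to land near compound 2, with the step of a 1.1-fold higher number from compound 2 to compound 4 (0.05 log units; within the scatter) expected to remain within the scatter, though the direction is uncertain. For compound 4 the estimate in this assay is 500 nM, with a range from 150 nM to 1600 nM.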

Compound 4, half-maximal inhibitory concentration: 3620 nM
Compound 4: middle estimate off by 7.2-fold (0.86 log units), on the low side, and the stated range ends below it.
By their numbers in this assay, from the lowest: compounds 1 and 2 (each within the scatter of the next); then compound 3; then compound 4.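

The 3,4,5-trimethoxyphenyl ring shows that a substituent on the ring at this carbon does not by itself bring the number down in this assay: with a 3.2-fold higher number from compound 3 to compound 4 (0.51 log units; beyond the scatter) on going from the bare phenyl, compound 4 goes against the pattern that compounds 1 and 2 had suggested, in which the substituted rings gave lower numbers than phenyl. The position is therefore far less forgiving than the first three compounds implied, as the aryl swap alone gives an 8.0-fold higher number from compound 2 to compound 4 (0.91 log units; beyond the scatter) and also a 13-fold higher number from compound 1 to compound 4 (1.11 log units; beyond the scatter) on the same core, so that the identity of the substituents counts for more here than their presence. No measurement is at hand that explains why this ring, with its 12 heavy atoms and 3 hydrogen-bond acceptors, stands apart from the others.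

The compounds shown leave open whether the higher number goes with the three methoxy groups taken together or with any one of them alone. From the compounds shown here alone, how a ring carrying a single methoxy group, an amine or a carboxylic acid would read in this assay also remains open.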